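The source may report more compounds than this note shows. Statements on the series, on what has been measured and on what is new or still open speak of the compounds shown alone.

Working notes on a series built on one shared core, each member carrying a substituted phenyl on an aromatic nitrogen of a five-membered aromatic ring with three nitrogens. Compound 1 `Cc1ccccc1-n1nncc1CN1C(=O)C2(C(C#N)=C(N)Oc3c(N)cc4nc5ccccc5nc4c32)c2ccccc21` carries 2-methylphenyl there; in a functional assay on HCT-116 cells (Homo sapiens) for antiproliferative activity, read by MTT assay, with a stated time of 48 h (on this read-out lower numbers stand for stronger inhibition and higher numbers for weaker inhibition), compound 1 gives only a limit, > 50000 nM. Compound 2 `N#CC1=C(N)Oc2c(N)cc3nc4ccccc4nc3c2C12C(=O)N(Cc1cnnn1-c1ccc(F)cc1)c1ccccc12` carries 4-fluorophenyl; in this assay compound 2 likewise gives only a limit, > 50000 nM. Compound 3 `CC(=O)Nc1ccc(-n2nncc2CN2C(=O)C3(C(C#N)=C(N)Oc4c(N)cc5nc6ccccc6nc5c43)c3ccccc32)cc1` carries 4-acetamidophenyl; in this assay compound 3 also gives only a limit, > 50000 nM. Compound 3 thus stands at the same limit as the two others, and nothing separates the three on the numbers shown. The steps a step that the two limits leave unreadable from compound 1 to compound 2, a step that the two limits leave unreadable from compound 1 to compound 3 and a step that the two limits leave unreadable from compound 2 to compound 3 have no readable size, each lying between two limits. the limit of > 50000 nM in this assay, at which 3 of the 3 values shown sit, is the whole of the evidence.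

Compound 4 `Cc1ccc(C)c(-n2nncc2CN2C(=O)C3(C(C#N)=C(N)Oc4c(N)cc5nc6ccccc6nc5c43)c3ccccc32)c1` is the next member to be tested, differing from compound 3 in 2,5-dimethylphenyl in place of 4-acetamidophenyl on an aromatic nitrogen. Among the compounds with values here, no measured step gives a readable size for a change of the group on this nitrogen, so no direction beyond the scatter can be inferred; the expectation rests on (the limit of > 50000 nM in this assay, at which 3 of the 3 values shown sit). Compound 4 is expected to show in this assay a value of 60000 nM, range 15000 nM to 200000 nM, most probably reported again only as a limit. The expected step is a step that the limit leaves unreadable from compound 3 to compound 4, none beyond the scatter.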

Compound 4, half-maximal inhibitory concentration: > 50000 nM
Compound 4: no number, only a limit; the forecaster's own chance of this, stated with the estimate: 80%; the middle value is on the limit's open side.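

In this assay compound 4 gives only a limit, > 50000 nM, so the result adds no number to the series. Within the data shown here, no step from compound 1, compound 2 or compound 3 to compound 4 can be read, and the record stands as follows: the limit of > 50000 nM in this assay, at which 4 of the 4 values shown sit. The compounds shown leave open whether any substituted phenyl on this nitrogen of the shared core gives a measurable value in this assay.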